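The compounds below may be only part of what the source reports. "The series", "measured", "known", "first", "only" and "open" are said of these compounds alone.

Measured so far:
compound 1 `c1cncc(-c2ccccc2OCC2=NCCN2)c1`, in a functional assay for activation of Alpha-1B adrenergic receptor (Homo sapiens), read by calcium flux (on this read-out lower numbers stand for an effect already at smaller amounts and higher numbers for an effect only at larger amounts of compound), giving 79.4 nM
compound 2 `c1cnc(-c2ccccc2OCC2=NCCN2)nc1`, giving < 100000 nM, which is a limit of this assay and not a number
compound 3 `Cc1csc(-c2ccccc2OCC2=NCCN2)n1`, giving < 100000 nM, also a limit and not a number

For the measured compounds named here, compound 1 thus carries the only number among the three; the other two results sit at the limit of < 100000 nM in this assay, at which 2 of the 3 values shown sit. Compound 4 `Cn1nccc1-c1ccccc1OCC1=NCCN1` is still unmeasured and differs from compound 1 in one place: 1-methyl-1H-pyrazol-5-yl in place of pyridin-3-yl on an aromatic carbon. The nearest measured steps, a step that the limit leaves unreadable from compound 1 to compound 2 and a step that the limit leaves unreadable from compound 1 to compound 3, both exchange the same pyridin-3-yl for another small aromatic ring, yet their size cannot be read. The step to compound 4 is therefore expected to be a 19-fold higher number from compound 1 to compound 4 (1.28 log units; beyond the scatter), with wide uncertainty. Compound 4 is estimated at 1500 nM, between 100 nM and 30000 nM.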

Compound 4, half-maximal effective concentration: < 100000 nM
Compound 4 gave a limit, no number; the forecaster's own chance of this, stated with the estimate: 40%; the middle value lies beyond the limit too.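

Compound 4 gave only a limit, so its steps from compound 1, compound 2 and compound 3 cannot be read. The compounds shown leave open how far compound 2, compound 3 and compound 4 really lie from compound 1 in this assay.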